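Cytotoxicity series on a shared core: amine substituent changes

The compounds below may be only part of what the source reports. "The series", "measured", "known", "first", "only" and "open" are said of these compounds alone.

Measured so far:
compound 1 `N#CC1=C(NC(=S)Nc2ccc(Br)cc2)N(c2ccc(S(N)(=O)=O)cc2)C2=C(C(=O)CCC2)C1c1ccc(Cl)cc1Cl` — 50%
compound 2 `N#CC1=C(NC(=O)CCC(=O)O)N(c2ccc(S(N)(=O)=O)cc2)C2=C(C(=O)CCC2)C1c1ccc(Cl)cc1Cl` — 20%

In a functional assay on Ehrlich cells (Mus musculus) for cytotoxicity, read by trypan blue exclusion, with a stated time of 2 h, tested at 10 ug/mL (a lower number here means a weaker effect, a higher number a stronger effect of the compound at the concentration tested), compound 1 gives 50%, while compound 2 gives 20%, the lowest of the two numbers. For the measured compounds named here, the only measured step in this assay, a number 30 percentage points lower from compound 1 to compound 2 (beyond the scatter), accompanies the loss of the aromatic ring on the amine nitrogen.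

Compound 3 `N#CC1=C(NS(=O)(=O)c2ccc([N+](=O)[O-])cc2)N(c2ccc(S(N)(=O)=O)cc2)C2=C(C(=O)CCC2)C1c1ccc(Cl)cc1Cl` is not yet measured. It differs from compound 2 by (4-nitrophenyl)sulfonyl in place of (2-carboxyethyl)carbonyl on an amine nitrogen. Like the group that left compound 1, the entering group carries a six-membered aromatic ring of carbon only, so the step of a number 30 percentage points lower from compound 1 to compound 2 (beyond the scatter) is the one that bears on it, though the entering groups differ.

Given that this step was modest and in the falling direction when the ring left, a rise of similar size is expected on its return, so the expected step is a number 20 percentage points higher from compound 2 to compound 3 (beyond the scatter). Compound 3 is estimated at 40%, ranging from 20% to 60%.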

Compound 3, a percentage reported as activity, at one concentration (the size of the read-out at that concentration, not a potency): 50%
Beside the measured number, compound 3's estimate is 10 percentage points below it; the measured number falls inside the stated range.
By their numbers in this assay, from the lowest: compound 2; then compounds 1 and 3 (each within the scatter of the next).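

In this assay, a number 30 percentage points higher from compound 2 to compound 3 (beyond the scatter) with (4-nitrophenyl)sulfonyl in place of (2-carboxyethyl)carbonyl, so on this amine nitrogen the fall seen earlier has a counterpart in the rising direction, with a different ring-bearing group. For the compounds shown here, the ring-bearing groups of compound 1 and compound 3 differ in their atoms, yet no change at the digits printed from compound 1 to compound 3 (within the scatter), so here the six-membered aromatic ring of carbon only goes with the higher numbers, and compound 2, the only ring-free compound, goes against no part of this pattern. No measured evidence accounts for these numbers.

Going by these compounds alone, with only one ring-free group, it remains open whether the ring or some other part of the entering groups tracks the read-out. A cyclohexyl group or a plain acetyl on this nitrogen would help to separate the two, and all three readings remain single-concentration values rather than potencies.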